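The compounds below may be only part of what the source reports. "The series", "measured", "known", "first", "only" and "open" are said of these compounds alone.

Within the data shown here, in a functional assay on HT-29 cells (Homo sapiens) for cytotoxicity, read by MTT assay, with a stated time of 72 h (on this read-out lower numbers stand for stronger inhibition and higher numbers for weaker inhibition), compound 1 (`CCOC(=O)c1sc2ccccc2c1Nc1cc(OC)c(OC)c(OC)c1`) gives 1610 nM, the middle of the three numbers measured so far. Compound 3 (`CCOC(=O)c1sc2cccc(C)c2c1Nc1cc(OC)c(OC)c(OC)c1`) gives 3610 nM, while compound 2 (`COC(=O)c1sc2nc(C)ccc2c1Nc1cc(OC)c(OC)c(OC)c1`) gives 0.35 nM, far lower than the other two. Compound 2 differs from compound 1 in more than one place, so it offers little guidance on a single small change.

Compound 4 (`CCOC(=O)c1sc2cc(C)ccc2c1Nc1cc(OC)c(OC)c(OC)c1`) is compound 1 with one edit: methyl in place of hydrogen on an aromatic carbon. A methyl replaces a hydrogen on an aromatic carbon of a six-membered aromatic ring of carbon only, meta to a fused ring and para to a fused ring.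

Among the measured compounds shown here, compound 3 carries the same kind of change at a different aromatic carbon, which makes it the only direct guide. The measured step is a 2.2-fold higher number from compound 1 to compound 3 (0.35 log units; beyond the scatter), a modest one. A single example cannot show how much the place of the methyl matters, so a step of similar or smaller size toward a higher number in this assay is expected, and it may not rise beyond the scatter. The expected step is a 1.6-fold higher number from compound 1 to compound 4 (0.19 log units; within the scatter). Compound 4 is estimated at 2500 nM, with an expected range from 700 nM to 8000 nM.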

Compound 4, half-maximal inhibitory concentration: 6 nM
Estimate against measurement, compound 4: 420-fold (2.62 log units) above, and the stated range ends above it.
By their numbers in this assay, from the lowest: compound 2; then compound 4; then compound 1; then compound 3.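

In this assay, methyl in place of hydrogen gives a 270-fold lower number from compound 1 to compound 4 (2.43 log units; beyond the scatter), whereas the same kind of edit at a different aromatic carbon gives a 2.2-fold higher number from compound 1 to compound 3 (0.35 log units; beyond the scatter), so the two steps run in opposite directions and differ greatly in size. Compound 1 alone could not show this, and neither could the step to compound 3: the effect of this small edit depends strongly on where the methyl sits on the ring, and the carbon meta to a fused ring and para to a fused ring stands out among the two places shown. No measurement available here explains why these two places differ so much.

Still open, on these data alone, is whether this carbon favours methyl specifically, or whether a fluorine atom, an amine or a longer chain such as propyl in the same place would also give a low number. Also open, as far as these compounds go, is how much of the low number of compound 2, at 0.35 nM, comes from any one of its differences from compound 1, as several changes are combined in that compound and none can be read alone.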